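The source may hold more compounds than are shown below. What is called first, only, known or untested is meant among the compounds shown, and "the series" means these compounds.

Working notes on the series. Compound 1, `COc1ccccc1-c1n[nH]cc1N1CCNCC1`, was measured in an assay on isolated protein for binding affinity to 5-hydroxytryptamine receptor 1D (Homo sapiens) (a higher number here means a weaker inhibitor, a lower number a stronger inhibitor), where compound 1 gives > 10000 nM, a limit of the assay. Compound 2, `c1ccc(-c2n[nH]cc2N2CCNCC2)cc1`, gives > 10000 nM in this assay, also a limit. The step from compound 1 to compound 2, hydrogen in place of methoxy on an aromatic carbon, is a step that the two limits leave unreadable from compound 1 to compound 2; its size cannot be read because of the limit of > 10000 nM in this assay, at which 2 of the 2 values shown sit. Compound 2 therefore stands only at a limit of this assay, with no number to place it.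

Compound 3, `Clc1ccccc1-c1n[nH]cc1N1CCNCC1`, differs from compound 2 by chloro in place of hydrogen on an aromatic carbon. Among the compounds with values here, the only measured step bears on the same position but is unreadable, so there is no measured guide to the size or direction of the change in this assay, and the step from compound 2 to compound 3 may itself end at the limit. The expected step is estimated as a step that the limit leaves unreadable from compound 2 to compound 3. Compound 3 is expected near 15000 nM, with a range from 3000 nM to 60000 nM.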

Compound 3, inhibition constant: > 10000 nM
Compound 3: only a limit was reported (the forecaster's own chance of this, stated with the estimate: 70%); the middle value lies beyond the limit too.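

No step among compound 1, compound 2 and compound 3 can be read in this assay, because all three stand at a limit of the assay: the limit of > 10000 nM in this assay, at which 3 of the 3 values shown sit.

The compounds shown leave open whether methoxy, hydrogen and chloro on this aromatic carbon differ at all in binding affinity.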